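Selenocyanate quinazoline series: breast cancer cell inhibition notes

The source may report more compounds than this note shows. Statements on the series, on what has been measured and on what is new or still open speak of the compounds shown alone.

Measured so far:
compound 1 `Cc1nc(N(C)c2ccc([Se]C#N)c(Cl)c2)c2ccccc2n1` — 9 nM
compound 2 `COc1ccc(N(C)c2nc(C)nc3ccccc23)cc1C(=O)NCC[Se]C#N` — 1250 nM
compound 3 `C[Se]c1ccc(N(C)c2nc(C3CC3)nc3ccccc23)cc1` — 18 nM

In a functional assay on MDA-MB-231 cells (Homo sapiens) for inhibition, read by MTT assay, with a stated time of 48 h (a higher number here means a weaker inhibitor, a lower number a stronger inhibitor), compound 2 gives 1250 nM, the highest of the three numbers; compound 3 at 18 nM and compound 1 at 9 nM both sit well below it, beyond the scatter. For the measured compounds named here, no pair among the measured compounds differs in a single place, so no step can be read directly.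

Compound 4 `COc1ccc(N(C)c2nc(C)nc3ccccc23)cc1C(=O)OCC[Se]C#N` remains to be measured. It differs from compound 2 by a group of 6 heavy atoms (3 carbon, 1 nitrogen, 1 oxygen, 1 selenium; no ring) in place of a group of 6 heavy atoms (3 carbon, 2 nitrogen, 1 selenium; no ring), on a carbonyl carbon. Going by the values given here, the change is confined to the carbonyl carbon, and the data give no step of this kind to lean on. The expectation for compound 4 in this assay is therefore a step of a 1.1-fold lower number from compound 2 to compound 4 (0.06 log units; within the scatter) of no size beyond the scatter, leaving compound 4 near compound 2; the estimate is 1100 nM with a range of 300 nM to 4000 nM.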

Compound 4, half-maximal inhibitory concentration: 1480 nM
Compound 4: the middle estimate sits 1.3-fold (0.13 log units) below what was measured, within the range that was stated.
By their numbers in this assay, from the lowest: compounds 1 and 3 (each within the scatter of the next); then compounds 2 and 4 (each within the scatter of the next).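

On the carbonyl carbon, the group with 1 oxygen and 1 nitrogen in place of the group with 2 nitrogens, carrying 0 hydrogen-bond donors in place of 1, gives a 1.2-fold higher number from compound 2 to compound 4 (0.07 log units; within the scatter) in this assay. For the compounds shown here, this is the first single-place comparison, and at this position the two groups cannot be told apart in this assay. No further measurement bears on this result. Steps from these two compounds to compound 1 or compound 3 cannot be read. Open, as far as these compounds go, is how a carboxylic acid on this carbonyl carbon, or a longer chain carrying the selenocyanate, would compare with compound 2.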